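The source may hold more compounds than are shown below. What is called first, only, known or untested is meant among the compounds shown, and "the series" means these compounds.

The measured compounds, with their half-maximal inhibitory concentrations in a functional assay on CCRF-CEM cells (Homo sapiens) for inhibition; on this read-out higher numbers stand for weaker inhibition and lower numbers for stronger inhibition:

compound 1, `O=C1/C(=C/c2ccc(F)cc2)Cc2ccccc21`, gives 42200 nM
compound 2, `O=C1/C(=C/c2ccc(Cl)cc2)Cc2ccccc21`, gives 284000 nM
compound 3, `O=C1/C(=C/c2ccc(F)cc2)CCCc2ccccc21`, gives 20000 nM

Compound 1 and compound 2 share one core and differ in a single place: chloro in place of fluoro on an aromatic carbon. That change made a step of a 6.7-fold higher number from compound 1 to compound 2 (0.83 log units; beyond the scatter), so in this assay compound 2 is the weaker inhibitor of the two. Compound 3 carries a different core; how the two cores differ is not broken down here. Among the three measured compounds, compound 3 gives the lowest number, and its gaps to compound 1 and to compound 2 lie beyond the usual scatter.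

The unmeasured compound 4, `O=C1/C(=C/c2ccc(Cl)cc2)CCCc2ccccc21`, stands to compound 3 as compound 2 stands to compound 1: chloro in place of fluoro on an aromatic carbon. The place of the change is described in the same words in both pairs, so this is the same change, applied on the core of compound 3 instead of the core of compound 1.

Going by the values given here, because the only measured example of this change, a 6.7-fold higher number from compound 1 to compound 2 (0.83 log units; beyond the scatter), pointed toward a weaker inhibitor, the step from compound 3 to compound 4 is expected to point the same way, at about a 5.5-fold higher number from compound 3 to compound 4 (0.74 log units; beyond the scatter), with wide room on either side since a single earlier example is a thin base. Compound 4 is therefore estimated to give 110000 nM in this assay, most likely between 30000 nM and 400000 nM.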

Compound 4, half-maximal inhibitory concentration: 15100 nM
Beside the measured number, compound 4's estimate is 7.3-fold (0.86 log units) above it, outside the stated range (below it).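

In this assay, putting chloro in place of fluoro on the core of compound 3 gave a 1.3-fold lower number from compound 3 to compound 4 (0.12 log units; within the scatter), so on this core the exchange produced no change that can be told apart from ordinary variation between repeated measurements. The loss of inhibition seen on the other core therefore did not carry over, and a change that matters on one core cannot be assumed to matter on another in this series: the same change on two cores in this assay, a 6.7-fold higher number (0.83 log units; beyond the scatter) from compound 1 to compound 2 and a 1.3-fold lower number (0.12 log units; within the scatter) from compound 3 to compound 4, 8.9-fold (0.95 log units) apart, beyond the scatter of two such steps

This shows that the effect of the exchange depends on the core it is made on, but it rests on just one pair of compounds per core, so it gives no reason why the cores behave differently and no rule for predicting the step on a third core.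

The compounds shown leave open whether other groups at the same place on the aromatic ring, such as bromo, methyl or methoxy, would also separate the two cores in this assay. They also leave open whether the difference between the cores would hold for an amine or a carboxylic acid at that place, or for any group elsewhere on the molecule.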